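The compounds below may be only part of what the source reports. "The series", "measured", "known", "first", "only" and "open" are said of these compounds alone.

Values measured so far in an ADME assay on microsomes from liver (Mus musculus) for metabolic stability (a lower number here means that the compound disappears faster, a higher number that the compound lasts longer), are these:

- compound 1 `CCO[C@@H]1O[C@H](CNC(=O)c2ccc(S(N)(=O)=O)cc2)[C@@H](O)[C@H](O)[C@H]1O` gives 59.5 h
- compound 2 `CCCO[C@@H]1O[C@H](CNC(=O)c2ccc(S(N)(=O)=O)cc2)[C@H](O)[C@H](O)[C@H]1O` gives 66.4 h
- compound 3 `CCCO[C@@H]1O[C@H](CNC(=O)c2ccc(S(N)(=O)=O)cc2)[C@@H](O)[C@H](O)[C@H]1N` gives 64.4 h

The account follows the step from compound 3 to the still unmeasured compound 4 `CCCO[C@@H]1O[C@H](CNC(=O)c2ccc(S(N)(=O)=O)cc2)[C@@H](O)[C@H](O)[C@H]1O`. Compound 3 stands with compound 1 and compound 2 in one narrow group, and its half-life lies within the usual scatter of both. No order among the three can be read from these numbers.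

Compound 4 carries hydroxy in place of amino on a saturated ring carbon. The rest of the structure stays as it is in compound 3.

Among the compounds with values here, no measured pair in this set differs in one place only, so the data give no direct size for this change. Within the data shown here, they show only that compound 1 at 59.5 h and compound 2 at 66.4 h lie within the scatter of compound 3, even though their structures are not the same. On that basis, no change beyond the scatter is expected in this assay. The expected step of a 1.0-fold lower number from compound 3 to compound 4 (0.01 log units; within the scatter) is therefore small and has no clear direction. For compound 4 the estimated half-life is 63 h, with an expected range from 36 h to 110 h.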

Compound 4, half-life: 60 h
The estimate for compound 4 lay 1.1-fold (0.02 log units) above the measured number, within the range that was stated.
By their numbers in this assay, from the lowest: compounds 1, 4, 3 and 2 (each within the scatter of the next).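

In this assay, hydroxy in place of amino on a saturated ring carbon now has a measured size, a 1.1-fold lower number from compound 3 to compound 4 (0.03 log units; within the scatter), so this exchange at this position leaves the half-life where it was within the scatter. The same result gives two further comparisons in one place: inverting a stereocentre at a saturated ring carbon, drawn R in one compound and S in the other, comes to a 1.1-fold lower number from compound 2 to compound 4 (0.04 log units; within the scatter), and methyl in place of hydrogen on a saturated chain carbon, two bonds along the chain from an oxygen on a saturated carbon, comes to a 1.0-fold higher number from compound 1 to compound 4 (0.00 log units; within the scatter). The stereocentre comparison can be read for configuration alone because of one fact: the fact that compounds 2 and 4 differ only in the configuration as drawn.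

Each of these changes is seen only once, on this one core, so none of them can be said to hold on other compounds. Still open, from the compounds shown here alone, is whether a methoxy group or a fluorine on that saturated ring carbon, or a butoxy chain in place of the propoxy group, would also stay within the scatter.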